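Notes on a triazolylmethyl series in a pancreatic cell assay

The source may hold more compounds than are shown below. What is called first, only, known or untested is meant among the compounds shown, and "the series" means these compounds.

Three members of the series have been run in a functional assay on CFPAC-1 cells (Homo sapiens) for antiproliferative activity, read by MTT assay, with a stated time of 72 h; on this read-out higher numbers stand for weaker inhibition and lower numbers for stronger inhibition. Compound 1 `CCCCCc1ccc(C#Cc2c(-c3ccc(CCCCC)cc3)oc3nc(=O)n(Cc4cn(-c5ccc(Cl)cc5)nn4)cc23)cc1` reaches only the limit of the assay, > 100000 nM. Compound 2 `CCCCCCC#Cc1c(CCCCCC)oc2nc(=O)n(Cc3cn(-c4ccc(F)cc4)nn3)cc12` likewise gives only the limit, > 100000 nM. Compound 3 `CCCCCCC#Cc1c(CCCCCC)oc2nc(=O)n(Cc3cn(-c4ccc(Cl)cc4)nn3)cc12` also stops at the limit, > 100000 nM. For the measured compounds named here, all three values sit at the limit of > 100000 nM in this assay, at which 3 of the 3 values shown sit, so the single one-point step, a step that the two limits leave unreadable from compound 2 to compound 3, cannot be given a size. Compound 3 therefore stands at the limit, not separable from the other two compounds on the numbers shown.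

Compound 4 `CCCCCCC#Cc1c(CCCCCC)oc2nc(=O)n(Cc3cn(Cc4ccccc4)nn3)cc12` differs from compound 3 in one place: benzyl in place of 4-chlorophenyl on an aromatic nitrogen. Going by the values given here, no measured step touches this change, and the only measured step is itself unreadable. Because every value rests at the limit of > 100000 nM in this assay, at which 3 of the 3 values shown sit, no movement beyond the scatter is expected in this assay. The expected step is a step that the limit leaves unreadable from compound 3 to compound 4. Compound 4 is thus estimated at 150000 nM in this assay, within 50000 nM to 500000 nM, most likely reported again only as a limit.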

Compound 4, half-maximal inhibitory concentration: 27300 nM
The estimate for compound 4 lay 5.5-fold (0.74 log units) above the measured number; the measured number lies below the stated range.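

Benzyl in place of 4-chlorophenyl on an aromatic nitrogen gives the first readable movement in the series in this assay, with an at least 3.6-fold lower number from compound 3 to compound 4 (0.56 log units; beyond the scatter) as the result. The change from the 4-fluorophenyl compound reads the same way, as an at least 3.6-fold lower number from compound 2 to compound 4 (0.56 log units; beyond the scatter) shows, so this position can move the read-out, and both halogenated phenyl compounds stay on the weaker side of benzyl. On these data alone, both steps give only a minimum size, and the full gap stays unknown because compound 2 and compound 3 rest at a limit: the limit of > 100000 nM in this assay, at which 3 of the 4 values shown sit.

Open, as far as these compounds go, is how 4-chlorobenzyl, 2-phenylethyl or a longer alkyl chain would read on this nitrogen. Also open, from the compounds shown here alone, is whether benzyl would bring a similar movement on the core of compound 1.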